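The compounds below may be only part of what the source reports. "The series", "measured", "known", "first", "only" and "open" are said of these compounds alone.

In a functional assay on Caco-2 cells (Homo sapiens) for inhibition, read by sulforhodamine B assay, with a stated time of 72 h (a lower number here means a stronger inhibitor, a higher number a weaker inhibitor), compound 1 `CCCNC(=C\C(=O)/C=C/c1ccc(O)c(OC)c1)/C=C/c1ccc(O)c(OC)c1`, with propyl on an amine nitrogen, gives 22000 nM, while compound 2 `COc1cc(/C=C/C(=O)/C=C(/C=C/c2ccc(O)c(OC)c2)NC2CCCCC2)ccc1O`, with cyclohexyl there, gives 5100 nM. Compound 2 therefore holds the lower of the two numbers and is the stronger inhibitor of the pair. The unmeasured compound 3 `COc1cc(/C=C/C(=O)/C=C(/C=C/c2ccc(O)c(OC)c2)NCC(C)C)ccc1O` has isobutyl in place of cyclohexyl on an amine nitrogen. Going by the values given here, only one measured step bears on this change: a 4.3-fold lower number from compound 1 to compound 2 (0.63 log units; beyond the scatter), a modest step beyond the scatter, with cyclohexyl in place of propyl. Isobutyl, like propyl, has no ring, so part of that step is expected to reverse, giving a higher number in this assay. The expected change is a 2.4-fold higher number from compound 2 to compound 3 (0.37 log units; beyond the scatter). For compound 3 the estimated value is 12000 nM, with an expected range of 5500 nM to 26000 nM.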

Compound 3, half-maximal inhibitory concentration: > 25000 nM
Compound 3 was reported as a limit; the forecaster's own chance of this, stated with the estimate: 5%; at least 2.0-fold (0.31 log units) between middle value and limit.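

Compound 3 is reported in this assay only as a limit, so both of its steps are floors: the limit of > 25000 nM in this assay, at which 1 of the 3 values shown sits. Replacing cyclohexyl with isobutyl on the amine nitrogen gives an at least 4.9-fold higher number from compound 2 to compound 3 (0.69 log units; beyond the scatter), so the open-chain isobutyl does not keep the lower number seen with the ring-bearing cyclohexyl. Between the two open-chain groups, the comparison gives an at least 1.1-fold higher number from compound 1 to compound 3 (0.05 log units; that floor lies within the scatter), so no order can be read between propyl and isobutyl.

The compounds shown leave open whether the lower number of compound 2 goes with the ring itself or with the larger count of carbons. A cyclopentyl group or a straight hexyl chain on this nitrogen would separate those two readings, and a phenyl group would extend the question to an aromatic ring.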